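The compounds below may be only part of what the source reports. "The series", "measured", "known", "first", "only" and "open" are said of these compounds alone.

Three compounds on a shared core have been run in a functional assay on SH-SY5Y cells (Homo sapiens) for antiproliferative activity, with a stated time of 24 h, tested at 25 ug/mL; on this read-out higher numbers stand for a stronger effect at the one concentration tested and lower numbers for a weaker effect. Compound 1 `CC1=Cc2c(cc(C)oc2=O)OC1C` gives 43.8%. Compound 2 `CCC1C=Cc2c(cc(C)oc2=O)O1` gives 4.95%, and compound 3 `CCCCCCCCC1C=Cc2c(cc(C)oc2=O)O1` gives 60.1%. On these numbers compound 1 stands second highest of the three: compound 3 lies above it by a gap beyond the scatter, and compound 2 lies below it by a larger gap, also beyond the scatter.

Among the compounds with values here, only one pair of measured compounds differs in a single place, and that step, a number 55.2 percentage points higher from compound 2 to compound 3 (beyond the scatter), comes from hexyl in place of hydrogen on a saturated chain carbon, two bonds along the chain from a saturated ring carbon.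

Compound 4 `CC1=Cc2c(cc(C)oc2=O)OC1c1ccco1` is the next to be measured. Relative to compound 1 the change is furan-2-yl in place of methyl on a saturated ring carbon. Within the data shown here, the measured step concerns a chain carbon, not a saturated ring carbon, and no measured pair exchanges methyl for an aromatic ring at this place, so it bears only loosely on compound 4. Growth of the substituent raised the read-out in that step, which gives a weak lean upward, but with wide uncertainty.

Compound 4 is therefore expected to give about 50%, within a range of 25% to 75%, an estimated step of a number 6.2 percentage points higher from compound 1 to compound 4 (within the scatter).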

Compound 4, a percentage reported as inhibition, at one concentration (the size of the read-out at that concentration, not a potency): 64.3%
Compound 4: middle estimate off by 14.3 percentage points, on the low side, and the stated range covers the measured number.
By their numbers in this assay, from the lowest: compound 2; then compound 1; then compounds 3 and 4 (each within the scatter of the next).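

In this assay, the saturated ring carbon next to the ring oxygen accepts more than a methyl group: furan-2-yl in place of methyl gives a number 20.5 percentage points higher from compound 1 to compound 4 (beyond the scatter). Within the data shown here, this is the first direct reading at this position, since the earlier single-place step, a number 55.2 percentage points higher from compound 2 to compound 3 (beyond the scatter), concerned a saturated chain carbon and an added hexyl group rather than a ring carbon and an aromatic ring. The read-out can therefore rise beyond the scatter through a change on the ring carbon as well, although no measurement available here bears on why it rises.

Among these compounds, the one exchange at this position does not separate the contribution of the aromatic ring from that of its oxygen or of the added heavy atoms, and comparing phenyl, thiophen-2-yl and a hexyl chain at the same ring carbon would help to tell these apart. Also open, going by these compounds, are whether an amine or a carboxylic acid carried on the furan ring would keep the read-out, and whether the stronger effect seen at the one concentration tested would also hold at other concentrations.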